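The source may report more compounds than this note shows. Statements on the series, on what has been measured and on what is new or still open speak of the compounds shown alone.

Compounds measured so far in a functional assay, read by spectrophotometry, with a stated time of 30 min; a higher number here means that more compound is needed for the effect, a lower number that less compound is needed:
compound 1 `COc1cc(C2Oc3cc([C@H]4Oc5cc(O)cc(O)c5C(=O)[C@@H]4O)ccc3OC2COC(=O)c2ccc(N)cc2)ccc1O` gives 128000 nM
compound 2 `COc1cc(C2Oc3cc([C@H]4Oc5cc(O)cc(O)c5C(=O)[C@@H]4O)ccc3OC2COC(=O)c2cc(OC)c(OC)c(OC)c2)ccc1O` gives 94800 nM

Among the compounds with values here, compound 2 and compound 1 are the only two numbers, and they lie within the scatter of each other, so no order between them can be drawn. Compound 3 `COc1cc(C2Oc3cc([C@H]4Oc5cc(O)cc(O)c5C(=O)[C@@H]4O)ccc3OC2COC(=O)c2ccccc2)ccc1O` is still to be measured; it differs from compound 2 by the change (phenyl in place of 3,4,5-trimethoxyphenyl on a carbonyl carbon).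

Within the data shown here, only one measured step bears on this change: the one from compound 1 to compound 2, a 1.4-fold lower number from compound 1 to compound 2 (0.13 log units; within the scatter), in which the aryl group on the carbonyl carbon was also exchanged for another aryl group without moving the rest of the molecule. That exchange left the number within the scatter, so a further exchange of aryl group at the same carbonyl carbon is expected to do the same, with no step beyond the scatter in either direction. Compound 3 is therefore expected to give about 110000 nM, between 50000 nM and 250000 nM, which means an estimated step of a 1.2-fold higher number from compound 2 to compound 3 (0.06 log units; within the scatter).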

Compound 3, half-maximal effective concentration: 105000 nM
Estimate against measurement, compound 3: 1.0-fold (0.02 log units) above; low and high end bracket the measured number.
By their numbers in this assay, from the lowest: compounds 2, 3 and 1 (each within the scatter of the next).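

In this assay, phenyl in place of 3,4,5-trimethoxyphenyl on the carbonyl carbon gives a 1.1-fold higher number from compound 2 to compound 3 (0.04 log units; within the scatter), and hydrogen in place of amino on an aromatic carbon gives a 1.2-fold lower number from compound 1 to compound 3 (0.09 log units; within the scatter). Within the data shown here, the unsubstituted phenyl thus adds a reference point that the earlier compounds lacked: neither the amino group of compound 1 nor the three methoxy groups of compound 2 separates its compound from compound 3 beyond the scatter, and the three aryl esters cannot be ordered. No measurement is available that would explain this flat result.

From the compounds shown here alone, it remains open whether a group without an aromatic ring on this carbonyl carbon, such as a short alkyl chain, would leave the number in place. The same holds for an aryl group carrying a carboxylic acid or a halogen such as chlorine.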